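Methyl on the Ester Chain Across Two Ester Arrangements

The compounds below may be only part of what the source reports. "The series", "measured", "known", "first", "only" and "open" are said of these compounds alone.

compound 1, `CC[C@H](C)C(=O)Oc1ccc(/C=C/COC(C)=O)cc1OC`: 990 nM
compound 2, `CCCC(=O)OC/C=C/c1ccc(OC(C)=O)c(OC)c1`: 10200 nM
compound 3, `CCCC(=O)Oc1ccc(/C=C/COC(C)=O)cc1OC`: 7590 nM

Three compounds were tested in a functional assay on SW-620 cells (Homo sapiens) for antiproliferative activity, read by sulforhodamine B assay, with a stated time of 72 h; on this read-out higher numbers stand for weaker inhibition and lower numbers for stronger inhibition. Compound 3 and compound 1 share one core and differ in a single place: methyl in place of hydrogen on a saturated chain carbon bound to a carbonyl carbon and a saturated chain carbon. That change produced a 7.7-fold lower number from compound 3 to compound 1 (0.88 log units; beyond the scatter), a drop in the half-maximal inhibitory concentration that lies beyond the scatter of the assay. Compound 2 is built from the same atoms as compound 3, joined in another way; the difference between the two cores is not broken down here. In this assay compound 2 gives 10200 nM, and in the same assay compound 3 gives 7590 nM, so the two lie within the scatter of each other and no order between them can be claimed.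

Compound 4, `CC[C@H](C)C(=O)OC/C=C/c1ccc(OC(C)=O)c(OC)c1`, has not yet been measured. Among the compounds with values here, it differs from compound 2 by methyl in place of hydrogen on a saturated chain carbon bound to a carbonyl carbon and a saturated chain carbon, which is the same change, at the same place, as the one made from compound 3 to compound 1. Since compound 2 and compound 3 give values within the scatter of each other, compound 2 is expected to behave like compound 3 when the methyl is added. The step from compound 2 to compound 4 in this assay is expected to be a 6.8-fold lower number from compound 2 to compound 4 (0.83 log units; beyond the scatter), because the matching change gave a 7.7-fold lower number from compound 3 to compound 1 (0.88 log units; beyond the scatter); the different core adds uncertainty, so a wider range is allowed. Compound 4 is therefore estimated at 1500 nM in this assay, expected to fall between 500 nM and 5000 nM.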

Compound 4, half-maximal inhibitory concentration: 21900 nM
For compound 4 the middle estimate is 15-fold (1.16 log units) below the measured one, and the stated range ends below it.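

In this assay the methyl in place of hydrogen on the saturated chain carbon did not carry over from one core to the other: here it gave a 2.1-fold higher number from compound 2 to compound 4 (0.33 log units; beyond the scatter), a step in the opposite direction to the earlier one. Set side by side, the two results differ by more than the scatter allows: the same change on two cores in this assay, a 7.7-fold lower number (0.88 log units; beyond the scatter) from compound 3 to compound 1 and a 2.1-fold higher number (0.33 log units; beyond the scatter) from compound 2 to compound 4, 16-fold (1.22 log units) apart, beyond the scatter of two such steps. In this series, then, the step measured on the core of compound 3 could not be transferred to the core of compound 2, even though compound 2 and compound 3 themselves lie within the scatter of each other, so similar values for two parent compounds did not mean a similar response to the same change; this does not show why the two cores part ways, and one pair on each core says nothing about how any other change would carry over.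

The compounds shown leave open whether the same split between the two cores would appear with other groups on the ester chain, such as a longer chain, a cyclopropyl group or a carboxylic acid. They also leave open what the opposite configuration at the branched carbon of the sec-butyl group would give on either core.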